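The compounds below may be only part of what the source reports. "The series", "measured", "known", "first", "only" and "open" are said of these compounds alone.

Series notes. Among the measured compounds shown here, in an ADME assay on microsomes from liver (Mus musculus), read by LC-MS, using NADPH, with a stated time of 30 min, tested at 1 uM (on this read-out lower numbers stand for a less stable compound and higher numbers for a more stable compound), compound 1 `Cc1nc(N)nc(N[C@@H](C)c2cc3ccc(F)cn3c(=O)c2-c2ccccc2)c1C#N` gives 8%, while compound 2 `Cc1c([C@H](C)Nc2nc(N)nc(N)c2C#N)c(-c2ccccc2)c(=O)n2cc(F)ccc12` gives 85%; compound 2 stands highest of the two numbers, its only neighbour being compound 1, a gap beyond the scatter. For the measured compounds named here, the two differ in more than one place, so no single step is drawn between them. Compound 3 `Cc1nc(N)nc(N[C@@H](C)c2c(-c3ccccc3)c(=O)n3cc(F)ccc3c2C)c1C#N` carries the change (methyl in place of amino on an aromatic carbon), methyl in place of amino on an aromatic carbon. The resulting 2-amino-5-cyano-6-methylpyrimidin-4-yl group is also found in compound 1, whose 8% lies well under compound 2. A drop beyond the scatter is therefore expected, estimated as a number 40 percentage points lower from compound 2 to compound 3 (beyond the scatter). Compound 3 is expected at 45%, range 12% to 78%.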

Compound 3, percent of the compound remaining: 75%
Compound 3: the middle estimate sits 30 percentage points below what was measured; the measured number falls inside the stated range.
By their numbers in this assay, from the lowest: compound 1; then compounds 3 and 2 (each within the scatter of the next).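

In this assay, the 2-amino-5-cyano-6-methylpyrimidin-4-yl group does not by itself go with the low number of compound 1: amino and methyl at this position read alike, with a number 10 percentage points lower from compound 2 to compound 3 (within the scatter). The large separation lies instead with the added methyl on the core, a number 67 percentage points higher from compound 1 to compound 3 (beyond the scatter). Nothing available bears on the reason for either step. Open, on these data alone, is whether a methoxy or an ethyl group at this position would read alike, and whether the methyl on the core holds its effect alongside amino.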